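Carbonyl substituent changes on the shared core, working notes

The source may report more compounds than this note shows. Statements on the series, on what has been measured and on what is new or still open speak of the compounds shown alone.

Measured so far:
- compound 1 `COc1cc(-n2cccc2C(=O)O)ccc1Nc1ncc(Cl)c(Nc2ccccc2NS(C)(=O)=O)n1` gives 640 nM in a functional assay on NCI-H2228 cells (Homo sapiens) for antiproliferative activity, read by MTT assay, with a stated time of 72 h; a lower number here means a stronger inhibitor, a higher number a weaker inhibitor
- compound 2 `COc1cc(-n2cccc2C(=O)N2CCCCC2)ccc1Nc1ncc(Cl)c(Nc2ccccc2NS(C)(=O)=O)n1` gives 630 nM in this assay

Compound 1 and compound 2 sit together; the step of a 1.0-fold lower number from compound 1 to compound 2 (0.01 log units; within the scatter) is within the scatter, so neither can be ranked against the other on this assay. On the numbers shown, compound 1 is one of two equivalent values.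

Compound 3 `COc1cc(-n2cccc2C(=O)NCCO)ccc1Nc1ncc(Cl)c(Nc2ccccc2NS(C)(=O)=O)n1` has not been measured. It differs from compound 1 by (2-hydroxyethyl)amino in place of hydroxy on a carbonyl carbon. For the measured compounds named here, the only measured step at this position, a 1.0-fold lower number from compound 1 to compound 2 (0.01 log units; within the scatter), exchanges the hydroxy for a piperidin-1-yl group with no change beyond the scatter. Going by the values given here, the (2-hydroxyethyl)amino group entering in compound 3 sits on the same carbonyl carbon, and the one comparison available suggests the substituent there does little to the read-out in this assay. No step beyond the scatter is therefore expected; the estimated step is a 1.1-fold lower number from compound 1 to compound 3 (0.03 log units; within the scatter). Compound 3 is expected to give about 600 nM in this assay, with a range from 300 nM to 1300 nM.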

Compound 3, half-maximal inhibitory concentration: 34 nM
Beside the measured number, compound 3's estimate is 18-fold (1.25 log units) above it; measured number outside the range, below it.
By their numbers in this assay, from the lowest: compound 3; then compounds 2 and 1 (each within the scatter of the next).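

In this assay, the group on the carbonyl carbon does change the read-out: (2-hydroxyethyl)amino in place of hydroxy gives a 19-fold lower number from compound 1 to compound 3 (1.27 log units; beyond the scatter), and (2-hydroxyethyl)amino in place of piperidin-1-yl gives a 19-fold lower number from compound 2 to compound 3 (1.27 log units; beyond the scatter). The step between compound 1 and compound 2 therefore does not describe this position as a whole, since the hydroxy and piperidin-1-yl groups give equivalent numbers while the (2-hydroxyethyl)amino group of compound 3 stands apart from both. Nothing at hand gives a reason for this difference.

The compounds shown do not separate the contribution of the amide hydrogen from that of the terminal hydroxy of the (2-hydroxyethyl)amino group, a question that an ethylamino or a 2-methoxyethylamino group on the same carbonyl carbon would address. Also open, going by these compounds, is whether the step depends on chain length, as a 3-hydroxypropylamino group would show, and whether a 2-aminoethylamino group would serve in place of the (2-hydroxyethyl)amino group.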